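This account rests on a few compounds, and the source may have more. Where it says the series, first, only, none or still open, it means among the compounds named here.

Compound 1 `O=C(Cc1cccnc1)c1cc2ccccc2[nH]1` is the starting point of this account. In an in vitro assay on P815B cells for inhibition of Indoleamine 2,3-dioxygenase 1 (Mus musculus), tested at 20 uM (a lower number here means less inhibition, a higher number more inhibition at the concentration tested (going by the name of the read-out)), compound 1 gives 13%, and compound 2 `O=C(Cc1ccccn1)c1cc2ccccc2[nH]1` gives 10%, so that the step of a number 3 percentage points lower from compound 1 to compound 2 (within the scatter) stays within the scatter; compound 3 `O=C(Cc1cccnc1)c1[nH]c2ccccc2c1Br` is reported in this assay as "not active" (no number reported) without a number. Compound 4 `O=C(Cc1cccnc1)c1cc2ccc(F)cc2[nH]1` differs from compound 1 by fluoro in place of hydrogen on an aromatic carbon. For the measured compounds named here, no measured step concerns a fluoro entering on the core; the one step, a number 3 percentage points lower from compound 1 to compound 2 (within the scatter), touches only the pyridyl group and so cannot guide this change. Compound 4 is therefore expected to show no step beyond the scatter, no change at the digits printed from compound 1 to compound 4 (within the scatter), and its estimated reading in this assay is 13%, with a range from 3% to 25%.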

Compound 4, a percentage reported as inhibition, at one concentration (the size of the read-out at that concentration, not a potency): "not active" (no number reported)
Compound 4 has no reported number here; the estimate stays without a comparison.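

In this assay, for the compounds shown here, compound 4 stands as "not active" (no number reported) so no step from compound 1 to compound 4 can be read. No evidence at hand bears on this result. The compounds shown leave open whether fluoro in place of hydrogen on the core changes inhibition at all.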